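The source may hold more compounds than are shown below. What is called first, only, known or untested is meant among the compounds shown, and "the series" means these compounds.

Compound 1 `CC1(C)[C@H]2CC[C@]1(C)N(Cc1cn(-c3cccc(C#N)c3)nn1)C(=O)C2`: 230 nM
Compound 2 `CC1(C)[C@H]2CC[C@]1(C)N(Cc1cn(-c3ccccc3Cl)nn1)C(=O)C2`: 40 nM

Both numbers come from a functional assay on OVCAR-3 cells (Homo sapiens) for inhibition, read by MTT assay, with a stated time of 24 h; a lower number here means a stronger inhibitor, a higher number a weaker inhibitor. Compound 2 has the lowest number of the two measured compounds; its nearest neighbour is compound 1, separated by a 5.8-fold lower number from compound 1 to compound 2 (0.76 log units; beyond the scatter). Going by the values given here, this is the only measured step, and it shows that exchanging the substituted phenyl on the aromatic nitrogen can shift the number beyond the scatter. Compound 3 `CC1(C)[C@H]2CC[C@]1(C)N(Cc1cn(-c3ccc(O)cc3)nn1)C(=O)C2` is not yet measured. It differs from compound 2 in one place: 4-hydroxyphenyl in place of 2-chlorophenyl on an aromatic nitrogen. Among the compounds with values here, the step from compound 1 to compound 2 is the only one that bears on this change, and it bears only loosely, since no measured compound carries a hydroxyl group at that position. Given that the one measured exchange in this position moved the number by a modest amount, a step of a 3.8-fold higher number from compound 2 to compound 3 (0.57 log units; beyond the scatter) is expected for compound 3, toward a higher number. Compound 3 is therefore estimated at 150 nM, within a range from 40 nM to 600 nM.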

Compound 3, half-maximal inhibitory concentration: 410 nM
For compound 3 the middle estimate is 2.7-fold (0.44 log units) below the measured one; the range from low to high includes it.
By their numbers in this assay, from the lowest: compound 2; then compounds 1 and 3 (each within the scatter of the next).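

Exchanging 2-chlorophenyl for 4-hydroxyphenyl on the aromatic nitrogen gives a 10-fold higher number from compound 2 to compound 3 (1.01 log units; beyond the scatter) in this assay, a step rated large where the earlier step at this position was modest. The 4-hydroxyphenyl and 3-cyanophenyl groups, however, cannot be told apart, with a 1.8-fold higher number from compound 1 to compound 3 (0.25 log units; within the scatter) in this assay. Among these three groups, then, only 2-chlorophenyl stands clearly apart from the other two, while two different substituents on the phenyl ring give numbers that cannot be separated.

The compounds shown leave open whether the low number of compound 2 would survive with the chlorine moved, as in a 4-chlorophenyl group, and what a methoxy group or an amine on the phenyl ring would do. No information at hand explains why these groups differ as they do.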